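Chloro for trifluoromethyl on the pendant ring

The source may hold more compounds than are shown below. What is called first, only, known or untested is meant among the compounds shown, and "the series" means these compounds.

Three compounds share one core. Compound 1 `COc1cncc(-c2c(C)nn(-c3nc(-c4ccc(Cl)c(Cl)c4)c(SC(C)C)s3)c2C(=O)O)c1` gives 21000 nM in a functional assay on BJAB cells (Homo sapiens) for antiproliferative activity, with a stated time of 4 days; on this read-out higher numbers stand for an effect only at larger amounts of compound and lower numbers for an effect already at smaller amounts. Compound 2 `Cc1cc(C#N)cc(-c2c(C)nn(-c3nc(-c4ccc(Cl)c(Cl)c4)c(SC(C)C)s3)c2C(=O)O)c1` gives 4800 nM, and compound 3 `Cc1nn(-c2nc(-c3ccc(Cl)c(Cl)c3)c(SC(C)C)s2)c(C(=O)O)c1-c1ccccc1C(F)(F)F` gives 5200 nM. Compound 3 thus stands second highest of the three numbers: a 4.0-fold lower number from compound 1 to compound 3 (0.61 log units; beyond the scatter), while a 1.1-fold higher number from compound 2 to compound 3 (0.03 log units; within the scatter). Compound 4 `Cc1nn(-c2nc(-c3ccc(Cl)c(Cl)c3)c(SC(C)C)s2)c(C(=O)O)c1-c1ccccc1Cl` carries the change (chloro in place of trifluoromethyl on an aromatic carbon). Among the measured compounds shown here, no measured step exchanges one small group for another on this ring; the steps that replace the whole ring are a 4.4-fold lower number from compound 1 to compound 2 (0.64 log units; beyond the scatter), a 4.0-fold lower number from compound 1 to compound 3 (0.61 log units; beyond the scatter) and a 1.1-fold higher number from compound 2 to compound 3 (0.03 log units; within the scatter), the last showing that two quite different rings give the same number within scatter. A step no larger than the scatter is therefore expected, a 1.1-fold higher number from compound 3 to compound 4 (0.02 log units; within the scatter). Compound 4 is estimated at 5500 nM, within 2000 nM to 15000 nM.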

Compound 4, half-maximal effective concentration: 13100 nM
The estimate for compound 4 lay 2.4-fold (0.38 log units) below the measured number, and the stated range covers the measured number.
By their numbers in this assay, from the lowest: compounds 2 and 3 (each within the scatter of the next); then compounds 4 and 1 (each within the scatter of the next).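

With the ring kept, exchanging only the small group still moves the number: chloro in place of trifluoromethyl gives (a step the whole-ring replacements could not show) a 2.5-fold higher number from compound 3 to compound 4 (0.40 log units; beyond the scatter). The 2-chlorophenyl ring also separates from 3-cyano-5-methylphenyl (a 2.7-fold higher number from compound 2 to compound 4 (0.44 log units; beyond the scatter)) but not from 5-methoxypyridin-3-yl (a 1.6-fold lower number from compound 1 to compound 4 (0.20 log units; within the scatter)). No measurement at hand accounts for the chloro result.

Open, on these data alone, is how fluoro or an amine on this aromatic carbon would compare with chloro and trifluoromethyl. Also open, as far as these compounds go, is whether the step between these two groups holds on other pendant rings.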